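The source may hold more compounds than are shown below. What is called first, only, known or untested is meant among the compounds shown, and "the series" means these compounds.

Series values in a functional assay on ECa-109 cells (Homo sapiens) for antiproliferative activity, read by MTT assay, with a stated time of 48 h; on this read-out higher numbers stand for weaker inhibition and lower numbers for stronger inhibition:

- compound 1 `Cn1cc(C2=C(c3nn(CCCN4CCCCC4)c4ncccc34)C(=O)N(c3ccc(Cl)cc3)C2=O)c2ccccc21`: > 100000 nM (a limit)
- compound 2 `Cn1cc(C2=C(c3nn(CCCN4CCCCC4)c4ncccc34)C(=O)N(c3cccc4ccccc34)C2=O)c2ccccc21`: 1830 nM
- compound 3 `CN1CCN(CCCn2nc(C3=C(c4cn(C)c5ccccc45)C(=O)NC3=O)c3cccnc32)CC1`: > 100000 nM (a limit)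

Compound 3 gives only a limit, > 100000 nM, and no number. The same holds for one other compound, so the data show (the limit of > 100000 nM in this assay, at which 2 of the 3 values shown sit).

Compound 4 `Cn1cc(C2=C(c3nn(CCCCn4ccnc4)c4ncccc34)C(=O)NC2=O)c2ccccc21` is still to be measured. It replaces the 3-(4-methylpiperazin-1-yl)propyl chain of compound 3 with 4-(1H-imidazol-1-yl)butyl: (1H-imidazol-1-yl)methyl in place of 4-methylpiperazin-1-yl on a saturated chain carbon, three bonds along the chain from an aromatic nitrogen. The change is (1H-imidazol-1-yl)methyl in place of 4-methylpiperazin-1-yl on a saturated chain carbon, three bonds along the chain from an aromatic nitrogen.

Among the measured compounds shown here, no measured step covers this place. The only one, an at least 54-fold lower number from compound 1 to compound 2 (1.73 log units; beyond the scatter), is large, but it concerns the substituent on the amide-type nitrogen in a ring, where compound 4 keeps the amide hydrogen of compound 3. It therefore gives no direct guide to size or direction.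

A small shift toward a lower number is expected at most, an at least 2.0-fold lower number from compound 3 to compound 4 (0.30 log units; that floor lies within the scatter), and another limit would not surprise. For compound 4 the estimated value is 50000 nM, with an expected range of 8000 nM to 100000 nM.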

Compound 4, half-maximal inhibitory concentration: 23500 nM
Compound 4: middle estimate off by 2.1-fold (0.33 log units), on the high side, and the stated range covers the measured number.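

In this assay the change from 3-(4-methylpiperazin-1-yl)propyl to 4-(1H-imidazol-1-yl)butyl gives an at least 4.2-fold lower number from compound 3 to compound 4 (0.62 log units; beyond the scatter) and thus shows that this chain, and not only the substituent on the amide-type nitrogen in a ring, can move the read-out. Compound 4 keeps the amide hydrogen and still gives a number rather than a limit. The step is only a floor, since compound 3 is itself a limit: the limit of > 100000 nM in this assay, at which 2 of the 4 values shown sit.

From the compounds shown here alone, the change alters the ring and the chain length together, so the share of each stays open, and a 4-(4-methylpiperazin-1-yl)butyl or a 3-(1H-imidazol-1-yl)propyl chain would separate them. Also open, going by these compounds, are how a morpholine at the chain end would read and whether naphthalen-1-yl on the amide-type nitrogen would combine with the 4-(1H-imidazol-1-yl)butyl chain.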